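Removing one hydroxy from the lowest number in the set

This account rests on a few compounds, and the source may have more. Where it says the series, first, only, none or still open, it means among the compounds named here.

Compound 1 `CCCCCCCCc1ccc(CCC(N)CO)cc1` — > 10 mg/kg in a functional assay on the whole organism (spleen, spleen) with Rattus norvegicus as the target; a higher number here means that more compound is needed for the effect, a lower number that less compound is needed
Compound 2 `C=CCC(N)(CO)CCc1ccc(OCCCCCCC)cc1` — 1.9 mg/kg
Compound 3 `CCCCCCCCc1ccc(CCC(N)(CO)CCO)cc1` — 0.009 mg/kg

In this assay compound 1 gives only a limit, > 10 mg/kg, (the limit of > 10 mg/kg in this assay, at which 1 of the 3 values shown sits). Compound 3 stands lowest among the numbers shown, and compound 2 comes next with 1.9 mg/kg. Among the measured compounds shown here, the one step measured here, an at least 1100-fold lower number from compound 1 to compound 3 (3.04 log units; beyond the scatter), shows that adding the 2-hydroxyethyl brought the number down sharply.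

Compound 4 `CCCCCCCCc1ccc(CCC(C)(N)CCO)cc1` differs from compound 3 by hydrogen in place of hydroxy on a saturated chain carbon, two bonds along the chain from an amine nitrogen. This takes away part of what the measured step added: the hydroxy goes, while the hydroxymethyl becomes methyl and the rest of compound 3 is kept. For the measured compounds named here, no measured step removes a hydroxy on its own, so the only guide is the large step from compound 1 to compound 3, read as a partial reversal. A higher number for compound 4 is therefore expected, beyond the scatter but far short of the limit at which compound 1 sits, since one hydroxy-bearing chain remains. For compound 4 the expected step is a 17-fold higher number from compound 3 to compound 4 (1.22 log units; beyond the scatter). Compound 4 is estimated at 0.15 mg/kg, within 0.02 mg/kg to 1.5 mg/kg.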

Compound 4, dose for 50% inhibition: > 10 mg/kg
Compound 4 ended at the assay's limit; the forecaster's own chance of this, stated with the estimate: 5%; middle value at least 66-fold (1.82 log units) from the limit.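

Turning the hydroxymethyl into methyl gives, in this assay, an at least 1100-fold higher number from compound 3 to compound 4 (3.04 log units; beyond the scatter), so the 2-hydroxyethyl that compound 4 keeps does not bring the number down on its own. Compound 3 carries both hydroxy-bearing chains, and both neighbours that differ from it in one place lose its low number: compound 1 lacks the 2-hydroxyethyl, and compound 4 has methyl for the hydroxymethyl. Compound 4 gives only a limit, and the step between compound 1 and compound 4 cannot be read, since both sit at the same limit: the limit of > 10 mg/kg in this assay, at which 2 of the 4 values shown sit.

On these data alone, how far beyond that limit either compound lies stays open, so the two hydroxy-bearing chains cannot be ranked against each other. Also open, as far as these compounds go, is whether an amine or a carboxylic acid in place of this hydroxy would keep the low number of compound 3.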